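This account rests on a few compounds, and the source may have more. Where it says the series, first, only, none or still open, it means among the compounds named here.

Of the compounds shown here, three sharing one core have been tested in a functional assay on SW 1116 cells (Homo sapiens) for cytotoxicity, read by MTT assay, with a stated time of 48 h; on this read-out higher numbers stand for weaker inhibition and lower numbers for stronger inhibition. Compound 1 `O=C(CSc1nnc(-c2ccncc2)o1)N/N=C/c1ccc(Cl)cc1` gives 17000 nM. Compound 2 `O=C(CSc1nnc(-c2ccncc2)o1)N/N=C/c1ccc([N+](=O)[O-])cc1` gives 25800 nM. Compound 3 `COc1cccc(/C=N/NC(=O)CSc2nnc(-c3ccncc3)o2)c1` gives 16500 nM. Compound 2 stands at the highest of the three numbers, yet the gaps are small: a 1.5-fold higher number from compound 1 to compound 2 (0.18 log units; within the scatter), and a 1.6-fold lower number from compound 2 to compound 3 (0.19 log units; within the scatter), so the three sit together within the scatter, and none can be called stronger or weaker than another.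

Compound 4 `O=C(CSc1nnc(-c2ccncc2)o1)N/N=C/c1ccc(O)c(O)c1` has not yet been measured in this assay. It differs from compound 2 in one place: 3,4-dihydroxyphenyl in place of 4-nitrophenyl on a carbon with a double bond to nitrogen. Within the data shown here, two measured steps bear on this change, since both also swap the group on the carbon with a double bond to nitrogen: a 1.5-fold higher number from compound 1 to compound 2 (0.18 log units; within the scatter) and a 1.6-fold lower number from compound 2 to compound 3 (0.19 log units; within the scatter). Among the measured compounds shown here, neither moved the number beyond the scatter, and nothing among the measured compounds carries the 3,4-dihydroxyphenyl group, so there is no direct precedent for it. The expectation is therefore a step of no real size, a 1.4-fold lower number from compound 2 to compound 4 (0.13 log units; within the scatter), in either direction. For compound 4 the estimated value in this assay is 19000 nM, with a likely range from 9000 nM to 40000 nM.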

Compound 4, half-maximal inhibitory concentration: 1540 nM
Estimate against measurement, compound 4: 12-fold (1.09 log units) above; the measured number lies below the stated range.
By their numbers in this assay, from the lowest: compound 4; then compounds 3, 1 and 2 (each within the scatter of the next).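

In this assay, the group on the carbon with a double bond to nitrogen proves able to change the number a great deal: 3,4-dihydroxyphenyl gives a 17-fold lower number from compound 2 to compound 4 (1.22 log units; beyond the scatter), an 11-fold lower number from compound 3 to compound 4 (1.03 log units; beyond the scatter) and an 11-fold lower number from compound 1 to compound 4 (1.04 log units; beyond the scatter), all large steps, whereas the swaps among the 4-chlorophenyl, 4-nitrophenyl and 3-methoxyphenyl compounds stayed within the scatter. Compound 4 is therefore the strongest of the four, and the change from compound 2 also replaces a group with 0 hydrogen-bond donors by one with 2 hydrogen-bond donors, although that difference alone does not show what drives the step. No measurement at hand explains why this group stands apart from the others.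

The compounds shown leave open whether both hydroxyl groups are needed, since a phenyl ring carrying a single hydroxyl would separate the contribution of one from that of two. They also leave open whether other groups could do the same job, such as two methoxy groups in place of the two hydroxyls, or an amine or a carboxylic acid on the ring.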